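Sulfonyl ester acrylamide series: growth inhibition working notes

A few compounds are considered here, and "the series" means these few. Any claim that something is new, unique, unknown or untested is made for them only; others in the source may bear on it.

Compound 1 `N#C/C(=C\c1ccccc1OS(=O)(=O)c1ccccc1[N+](=O)[O-])C(=O)Nc1nnc(Cc2ccccc2)s1` is the reference point. In an ADME assay on HEK-293T cells (Homo sapiens) for inhibition, read by CCK-8 assay, with a stated time of 48 h, tested at 20 uM (a lower number here means less inhibition of growth, a higher number more inhibition of growth at the concentration tested), compound 1 gives 10%. Compound 2 `N#C/C(=C\c1ccccc1OS(=O)(=O)c1ccc(Cl)cc1)C(=O)Nc1nnc(Cc2ccccc2)s1` differs from it in one place, (4-chlorophenyl in place of 2-nitrophenyl on a sulfonyl sulfur), and in this assay compound 2 gives 25%; the step is a number 15 percentage points higher from compound 1 to compound 2 (beyond the scatter). Compound 3 `Cc1ccc(Cc2nnc(NC(=O)/C(C#N)=C/c3ccccc3OS(=O)(=O)c3ccccc3[N+](=O)[O-])s2)cc1` differs from compound 1 in the other end of the molecule, (methyl in place of hydrogen on an aromatic carbon). In this assay compound 3 gives 6%, and the step of a number 4 percentage points lower from compound 1 to compound 3 (within the scatter) does not separate compound 1 from compound 3. Compound 2 and compound 3 differ in both places at once, and their two values lie apart beyond the scatter.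

Compound 4 `Cc1ccc(Cc2nnc(NC(=O)/C(C#N)=C/c3ccccc3OS(=O)(=O)c3ccc(Cl)cc3)s2)cc1` is not yet measured. It differs from compound 3 by 4-chlorophenyl in place of 2-nitrophenyl on a sulfonyl sulfur, the same change as from compound 1 to compound 2, at a place described in the same words for both pairs. The two cores differ by methyl in place of hydrogen on an aromatic carbon.

Within the data shown here, only one earlier instance of this change exists, so the expectation rests on that single step. The expected step in this assay is a number 14 percentage points higher from compound 3 to compound 4 (beyond the scatter), taken as close in size to a number 15 percentage points higher from compound 1 to compound 2 (beyond the scatter). Because the step of a number 4 percentage points lower from compound 1 to compound 3 (within the scatter) lies within the scatter, the core of compound 3 is taken to behave much like the core of compound 1. Compound 4 is therefore estimated at 20%, with a range from 8% to 32%.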

Compound 4, percent growth inhibition at one concentration: 8%
Compound 4: the middle estimate sits 12 percentage points above what was measured; the range from low to high includes it.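

In this assay, exchanging 2-nitrophenyl for 4-chlorophenyl on the sulfonyl sulfur gives a number 2 percentage points higher from compound 3 to compound 4 (within the scatter), and the methyl change, read with 4-chlorophenyl in place, gives a number 17 percentage points lower from compound 2 to compound 4 (beyond the scatter). Among these compounds, although only the first instance of the sulfonyl exchange lies beyond the scatter, the two instances cannot be told apart, so these data neither establish that the step depends on the core nor prove that it carries over unchanged: the same change on two cores in this assay, a number 15 percentage points higher (beyond the scatter) from compound 1 to compound 2 and a number 2 percentage points higher (within the scatter) from compound 3 to compound 4, 13 percentage points apart, within the scatter of two such steps. The methyl change gives the same reading, and with only two instances of each change, no rule for transfer between cores can be drawn from this set of compounds: the same change on two cores in this assay, a number 4 percentage points lower (within the scatter) from compound 1 to compound 3 and a number 17 percentage points lower (beyond the scatter) from compound 2 to compound 4, 13 percentage points apart, within the scatter of two such steps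

Still open, on these data alone, is how the step behaves on the sulfonyl sulfur with other groups on the aromatic ring, such as an amine or a carboxylic acid in place of the chlorine of 4-chlorophenyl. Also open, as far as these compounds go, is whether a longer chain in place of the methyl of compound 3 and compound 4 would separate the two cores more clearly than the methyl does.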